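A difluoromethyl analogue awaiting its solubility reading

This account rests on a few compounds, and the source may have more. Where it says the series, first, only, none or still open, it means among the compounds named here.

- compound 1 `CS(=O)(=O)c1ccc(-n2nc(C(F)F)c(C#N)c2-c2ccccc2)cc1` with "not determined" (no result reported)
- compound 2 `CC1CCCN(c2c(C#N)c(C(F)F)nn2-c2ccc(S(C)(=O)=O)cc2)C1` with 50 ug/mL
- compound 3 `CS(=O)(=O)c1ccc(-n2nc(C(F)(F)F)c(C#N)c2NCC2CC2)cc1` with "not determined" (no result reported)

In a physicochemical assay for solubility (a lower number here means a less soluble compound, a higher number a more soluble compound), compound 3 has no single number, its entry reading "not determined" (no result reported) in the record, and compound 1 is likewise without one. The next structure is compound 4 `CS(=O)(=O)c1ccc(-n2nc(C(F)F)c(C#N)c2NCC2CC2)cc1` in the series. The change hydrogen in place of fluoro on a saturated chain carbon bound to an aromatic carbon and two fluorine atoms puts hydrogen in place of fluoro on a saturated chain carbon bound to an aromatic carbon and two fluorine atoms, trifluoromethyl to difluoromethyl. Within the data shown here, no measured step is available, so no shift beyond the usual scatter is expected in this assay in either direction. Among the measured compounds shown here, the estimate rests on compound 2 at 50 ug/mL as the only number. The estimated solubility of compound 4 is 40 ug/mL with 10 ug/mL and 150 ug/mL as the expected ends.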

Compound 4, solubility: > 200 ug/mL
Compound 4: no number, only a limit; the forecaster's own chance of this, stated with the estimate: 10%; at least 5.0-fold (0.69 log units) between middle value and limit.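

With difluoromethyl held constant, the substituent on the aromatic carbon proves able to move this read-out: in this assay, (cyclopropylmethyl)amino in place of 3-methylpiperidin-1-yl gives an at least 4.0-fold higher number from compound 2 to compound 4 (0.60 log units; beyond the scatter). Compound 4 reads as a limit of the assay and not as a number: the limit of > 200 ug/mL in this assay, at which 1 of the 4 values shown sits.

The trifluoromethyl to difluoromethyl step cannot be read, since compound 3 has no single number, so the fluorine change itself remains unresolved. Also open, from the compounds shown here alone, is what a morpholine or a carboxylic acid on that aromatic carbon would give.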